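The source may hold more compounds than are shown below. What is called first, only, known or untested is meant among the compounds shown, and "the series" means these compounds.

Series in a functional assay with Homo sapiens as the target; a higher number here means a weaker inhibitor, a lower number a stronger inhibitor:
compound 1 `CC(C)[C@H](NC(=O)COc1cccc2ccccc12)C(=O)N[C@@H](CC(=O)O)C(=O)COc1ccc(-c2ccccc2)cc1`: 38700 nM
compound 2 `CC(C)[C@H](NC(=O)COc1cccc2ccccc12)C(=O)N[C@@H](CC(=O)O)C(=O)COc1c(F)cccc1F`: > 100000 nM
compound 3 `CC(C)[C@H](NC(=O)COc1cccc2ccccc12)C(=O)N[C@@H](CC(=O)O)C(=O)COc1cc(F)c(F)cc1F`: 16700 nM

The entry for compound 2 is a limit of the assay, not a number. The lower of the two numeric values belongs to the last entry, a modest gain: a 2.3-fold lower number from compound 1 to compound 3 (0.36 log units; beyond the scatter).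

Next comes compound 4 `CC(C)[C@H](NC(=O)COc1cccc2ccccc12)C(=O)N[C@@H](CC(=O)O)C(=O)COc1c(F)c(F)cc(F)c1F`, which has 2,3,5,6-tetrafluorophenyl in place of 2,4,5-trifluorophenyl on an oxygen on a saturated carbon.

The nearest measured change swaps one fluorinated group for another, and it is large: an at least 5.9-fold lower number from compound 2 to compound 3 (0.77 log units; beyond the scatter). For the measured compounds named here, no measured step isolates the present swap, so the direction stays open and the range wide. In this assay, no step beyond the scatter is expected. The estimated step is a 1.4-fold lower number from compound 3 to compound 4 (0.14 log units; within the scatter). The estimate for compound 4 is 12000 nM, with an expected range of 2000 nM to 70000 nM.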

Compound 4, half-maximal inhibitory concentration: 6250 nM
The estimate for compound 4 lay 1.9-fold (0.28 log units) above the measured number, and the stated range covers the measured number.
By their numbers in this assay, from the lowest: compound 4; then compound 3; then compound 1. At a limit, above all of these: compound 2.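

In this assay, for the compounds shown here, 2,3,5,6-tetrafluorophenyl on the oxygen gives the lowest number so far, with a 2.7-fold lower number from compound 3 to compound 4 (0.43 log units; beyond the scatter) and a 6.2-fold lower number from compound 1 to compound 4 (0.79 log units; beyond the scatter). Across the three fluorinated compounds the number now falls as fluorine count rises, none going against this order, and the widest span is an at least 16-fold lower number from compound 2 to compound 4 (1.20 log units; beyond the scatter). That span rests on a limit of the assay for compound 2: the limit of > 100000 nM in this assay, at which 1 of the 4 values shown sits.

The compounds shown do not separate fluorine count from fluorine placement on the ring. From the compounds shown here alone, whether the order extends to pentafluorophenyl, or holds for a phenyl carrying a nitrile or trifluoromethyl, stays open.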